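A few compounds are considered here, and "the series" means these few. Any claim that something is new, unique, unknown or untested is made for them only; others in the source may bear on it.

Going by the values given here, compound 3 `C=CC(=O)Nc1cccc(NC(=O)CSc2nc(Nc3cccc(Cl)c3)c3ccccc3n2)c1` gives the lowest number of the three measured so far in a functional assay on PC-3 cells (Homo sapiens) for inhibition, read by MTT assay, with a stated time of 72 h (on this read-out higher numbers stand for weaker inhibition and lower numbers for stronger inhibition), namely 12300 nM. Compound 1 `O=C(CSc1nc(Nc2ccccc2)c2ccccc2n1)Nc1ccc(Cl)cc1` gives 12900 nM, a gap within the scatter, while compound 2 `O=C(CSc1nc(Nc2ccccc2)c2ccccc2n1)Nc1ccc([N+](=O)[O-])cc1` gives 25000 nM, a gap beyond it. The only single-point step shown, a 1.9-fold higher number from compound 1 to compound 2 (0.29 log units; within the scatter), concerns a different ring from the one changed here, so it gives little guidance. Compound 4 `C=CC(=O)Nc1cccc(NC(=O)CSc2nc(Nc3cc(OC)c(OC)c(OC)c3)c3ccccc3n2)c1` differs from compound 3 by 3,4,5-trimethoxyphenyl in place of 3-chlorophenyl on a nitrogen on an aromatic ring. Among the compounds with values here, no measured step touches this position, so the expectation rests on how close compounds 1 and 3 sit. Compound 4 is expected to stay near compound 3, with a step of a 1.2-fold lower number from compound 3 to compound 4 (0.09 log units; within the scatter), not beyond the scatter. The estimate for compound 4 is 10000 nM, with a range from 3000 nM to 30000 nM.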

Compound 4, half-maximal inhibitory concentration: > 50000 nM
Compound 4: only a limit was reported; the forecaster's own chance of this, stated with the estimate: 10%; middle value at least 5.0-fold (0.69 log units) from the limit.
By their numbers in this assay, from the lowest: compounds 3, 1 and 2 (each within the scatter of the next, the first and the last beyond it). At a limit, above all of these: compound 4.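

On a nitrogen on an aromatic ring, 3,4,5-trimethoxyphenyl in place of 3-chlorophenyl is not a neutral swap: in this assay it gives an at least 4.0-fold higher number from compound 3 to compound 4 (0.60 log units; beyond the scatter). This is the only step shown that lies beyond the scatter, so this position does respond to the group it carries. From the compounds shown here alone, compound 4 is reported only as a limit, so the true size of the step stays unknown: the limit of > 50000 nM in this assay, at which 1 of the 4 values shown sits.

The compounds shown cannot tell whether all three methoxy groups are needed for this loss. A phenyl ring carrying a single methoxy group or an amine remains an open case at this position.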